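Replacing the tetrazolylmethyl amide with a directly attached tetrazole

A few compounds are considered here, and "the series" means these few. Any claim that something is new, unique, unknown or untested is made for them only; others in the source may bear on it.

Compound 1 `O=C(O)c1cc(-c2ccc(-c3ccc(Cl)cc3Cl)cc2)n(-c2cccnc2)n1`: 47000 nM
Compound 2 `O=C(O)c1cc(-c2ccc(-c3ccc(Cl)cc3Cl)cc2)n(-c2ccccn2)n1`: > 100000 nM
Compound 3 `O=C(NCc1nn[nH]n1)c1cc(-c2ccc(-c3ccc(Cl)cc3Cl)cc2)n(-c2cccnc2)n1`: 13800 nM

In an assay on isolated protein for inhibition of methionine--tRNA ligase, cytoplasmic (Homo sapiens) (a lower number here means a stronger inhibitor, a higher number a weaker inhibitor), compound 3 gives the lowest of the two numbers shown; the nearest is compound 1, a step of a 3.4-fold lower number from compound 1 to compound 3 (0.53 log units; beyond the scatter) away. For compound 2 the result is only a limit of the assay, (the limit of > 100000 nM in this assay, at which 1 of the 3 values shown sits).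

Compound 4 `Clc1ccc(-c2ccc(-c3cc(-n4cnnn4)nn3-c3cccnc3)cc2)c(Cl)c1` differs from compound 3 in one place: 1H-tetrazol-1-yl in place of ((2H-tetrazol-5-yl)methyl)carbamoyl on an aromatic carbon. Among the compounds with values here, no measured step covers this change. Within the data shown here, the only related step, a 3.4-fold lower number from compound 1 to compound 3 (0.53 log units; beyond the scatter), shows that growing the acid into the tetrazolylmethyl amide gave a modest gain, and compound 4 loses both that amide and its carbonyl. The number for compound 4 is therefore expected to be higher, a step of a 2.2-fold higher number from compound 3 to compound 4 (0.34 log units; beyond the scatter), with a wide margin. The estimate for compound 4 is 30000 nM, between 8000 nM and 100000 nM.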

Compound 4, half-maximal inhibitory concentration: 10600 nM
Compound 4: middle estimate off by 2.8-fold (0.45 log units), on the high side, and the stated range covers the measured number.
By their numbers in this assay, from the lowest: compounds 4 and 3 (each within the scatter of the next); then compound 1. At a limit, above all of these: compound 2.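

Compound 4 shows that, at this position in this assay, the ((2H-tetrazol-5-yl)methyl)carbamoyl group can give way to the smaller 1H-tetrazol-1-yl, which has no hydrogen-bond donors, with a step inside the scatter (a 1.3-fold lower number from compound 3 to compound 4 (0.11 log units; within the scatter)). The modest gain over the carboxy group therefore does not need the amide (a 4.4-fold lower number from compound 1 to compound 4 (0.65 log units; beyond the scatter)). Nothing shown explains why these groups are interchangeable here. Open, from the compounds shown here alone, is whether a plain primary amide or a 1,2,4-triazol-1-yl group would serve as well, and whether pyridin-2-yl would be tolerated alongside the 1H-tetrazol-1-yl group.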